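Swapping a Sulfonyl Cap for an Acetyl on Piperazine

This account rests on a few compounds, and the source may have more. Where it says the series, first, only, none or still open, it means among the compounds named here.

Compound 2 `Cc1cc(C#N)cc(C)c1Oc1nc(Nc2ccc(C#N)cc2)ncc1/C=C/C(=O)N1CCN(S(C)(=O)=O)CC1` carries the shared core with a 4-(methylsulfonyl)piperazin-1-yl group on the carbonyl carbon. In an ADME assay on TZM cells (Homo sapiens) for cytotoxicity, with a stated time of 1 days (on this read-out lower numbers stand for higher toxicity in this test and higher numbers for lower toxicity in this test), compound 2 gives only a limit, > 179 nM. Compound 1 `COCCNC(=O)/C=C/c1cnc(Nc2ccc(C#N)cc2)nc1Oc1c(C)cc(C#N)cc1C` carries a (2-methoxyethyl)amino group on that same carbonyl carbon. In this assay compound 1 likewise gives only a limit, > 213 nM. The step that the two limits leave unreadable from compound 1 to compound 2 cannot be read in size or direction: both ends are limits, as the limit of > 179 nM in this assay, at which 1 of the 2 values shown sits, and the limit of > 213 nM in this assay, at which 1 of the 2 values shown sits, show. Compound 3 `CC(=O)N1CCN(C(=O)/C=C/c2cnc(Nc3ccc(C#N)cc3)nc2Oc2c(C)cc(C#N)cc2C)CC1` differs from compound 2 by acetyl in place of methylsulfonyl on an amine nitrogen in a ring. The single measured step, from compound 1 to compound 2, is unreadable, so no measured step bears on the exchange of acetyl for methylsulfonyl, and nothing among the shown values suggests that compound 3 would move beyond the scatter in either direction. Compound 3 is therefore expected to give about 250 nM, with a range from 100 nM to 800 nM, and this assay may well again report only a limit. The expected step is a step that the limit leaves unreadable from compound 2 to compound 3.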

Compound 3, half-maximal cytotoxic concentration: > 192 nM
Compound 3: a limit, no number (the forecaster's own chance of this, stated with the estimate: 75%); the middle value does not contradict the limit.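

In this assay compound 3 gives only a limit, > 192 nM. Among the compounds shown here, compound 1, compound 2 and compound 3 all end in limits, so no step among them can be read in size or direction. The compounds shown leave open where their actual cytotoxic concentrations lie, and whether acetyl and methylsulfonyl on the ring amine nitrogen differ at all.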